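The source may report more compounds than this note shows. Statements on the series, on what has been measured and on what is new or still open speak of the compounds shown alone.

In a functional assay on HCT-116 cells (Homo sapiens) for antiproliferative activity, read by MTT assay, with a stated time of 72 h (on this read-out lower numbers stand for stronger inhibition and higher numbers for weaker inhibition), compound 1 `COc1ncc(-c2ccc3c(c2)N(c2ccc(F)cc2)C(=O)CO3)cc1NS(=O)(=O)c1ccc(F)cc1` reports only a limit, > 40000 nM. Compound 2 `COc1ncc(-c2ccc3c(c2)N(C2CCCCC2)C(=O)CO3)cc1NS(=O)(=O)c1ccc(F)cc1` also reports only a limit, > 40000 nM. Within the data shown here, compound 3 `COc1ncc(-c2ccc3c(c2)N(C2CC2)C(=O)CO3)cc1NS(=O)(=O)c1ccc(F)cc1` gives 24300 nM, the only actual number among the three. Compound 4 `COc1ncc(-c2ccc3c(c2)N(C(C)C)C(=O)CO3)cc1NS(=O)(=O)c1ccc(F)cc1` differs from compound 3 at one place, with isopropyl in place of cyclopropyl on an amide-type nitrogen in a ring. Two measured steps at this nitrogen bear on the change: an at least 1.6-fold lower number from compound 1 to compound 3 (0.21 log units; that floor lies within the scatter) and an at least 1.6-fold lower number from compound 2 to compound 3 (0.21 log units; that floor lies within the scatter). Neither gives a firm size, so no step beyond the scatter is expected in this assay, and no direction is firmly indicated. The expected change is a 1.2-fold higher number from compound 3 to compound 4 (0.06 log units; within the scatter). Compound 4 is expected at about 28000 nM. The estimated range for compound 4 runs from 14000 nM to 45000 nM.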

Compound 4, half-maximal inhibitory concentration: 19200 nM
Compound 4: middle estimate off by 1.5-fold (0.16 log units), on the high side; measured number inside the range.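

In this assay cyclopropyl and isopropyl on this amide-type nitrogen, one with a three-membered ring and the other with no ring, fall within the scatter of each other (a 1.3-fold lower number from compound 3 to compound 4 (0.10 log units; within the scatter)). Compound 4 also gives steps at this nitrogen that clear the scatter, which compound 3 did not (an at least 2.0-fold lower number from compound 2 to compound 4 (0.31 log units; beyond the scatter)) and (an at least 2.0-fold lower number from compound 1 to compound 4 (0.31 log units; beyond the scatter)). Both are floors, as compound 1 and compound 2 report only a limit: the limit of > 40000 nM in this assay, at which 2 of the 4 values shown sit. On these data alone, the full size of these two steps stays open. Also open, as far as these compounds go, is what methyl, or a longer chain ending in an amine, would give at this nitrogen.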